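This account rests on a few compounds, and the source may have more. Where it says the series, first, only, none or still open, it means among the compounds named here.

Four compounds share a core in which two aromatic rings are joined directly, one of them bearing a fluorine, while the second ring carries a side chain that differs between two pairs. Compound 1 `COc1ccc(C(=O)/C=C/c2ccccc2-c2ccc(F)cc2)cc1` and compound 2 `COc1ccc(C(=O)/C=C/c2ccccc2-c2ccc(F)cc2)cc1OC` carry a chain with a carbonyl and a double bond leading to a methoxy-bearing ring. Compound 3 `COc1ccc(CNC(=O)c2ccccc2-c2ccc(F)cc2)cc1` and compound 4 `COc1ccc(CNC(=O)c2ccccc2-c2ccc(F)cc2)cc1OC` instead carry an amide whose nitrogen is linked through a single carbon to a methoxy-bearing ring. The difference between the two cores is not broken down here.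

In a functional assay on SW480 cells (Homo sapiens) for antiproliferative activity, read by sulforhodamine B assay, with a stated time of 48 h (a lower number here means a stronger inhibitor, a higher number a weaker inhibitor), compound 1 gives 8400 nM. In this assay compound 2 gives 8300 nM. The change between them is methoxy in place of hydrogen on an aromatic carbon, and it made a 1.0-fold lower number from compound 1 to compound 2 (0.01 log units; within the scatter). For compound 3 in this assay only a limit of the assay is reported, > 50000 nM; this is a limit, not a number, as noted in the limit of > 50000 nM in this assay, at which 1 of the 3 values shown sits.

Compound 4 differs from compound 3 by methoxy in place of hydrogen on an aromatic carbon, the same change as between compound 1 and compound 2. Because the same change made a 1.0-fold lower number from compound 1 to compound 2 (0.01 log units; within the scatter), the step is expected to be small again. For compound 4 the estimated step is a step that the limit leaves unreadable from compound 3 to compound 4. Compound 4 is therefore expected to give about 60000 nM, most likely again only a limit of the assay.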

Compound 4, half-maximal inhibitory concentration: > 50000 nM
Compound 4 ended at the assay's limit; the forecaster's own chance of this, stated with the estimate: 85%; the middle value is on the limit's open side.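

Compound 3 and compound 4 both sit at a limit of this assay and neither gives a number, so no size can be read for the step between them, because both values rest on that limit: the limit of > 50000 nM in this assay, at which 2 of the 4 values shown sit.

The compounds shown leave open whether methoxy in place of hydrogen on an aromatic carbon changes the activity at all when the side chain is the amide.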